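Changing the ring on the amide nitrogen of compound 1

The source may report more compounds than this note shows. Statements on the series, on what has been measured and on what is new or still open speak of the compounds shown alone.

Of the compounds shown here, three have numbers so far in a functional assay on FaDu cells (Homo sapiens) for cytotoxicity, read by MTT assay, with a stated time of 72 h; a higher number here means that more compound is tolerated, a lower number that less compound is tolerated. Compound 1 (`COc1ncc(NC(=O)C(=O)c2cn(C(C)C)c3ccccc23)cn1`) gives 171 nM, the lowest of the three and beyond the scatter of both others. Compound 3 (`CCn1cc(C(=O)C(=O)Nc2ccnc(OC)c2)c2ccccc21`) gives 4180 nM, and compound 2 (`COc1ccc(NC(=O)C(=O)c2cn(C(C)C)c3c(Cl)cccc23)cn1`) gives 10200 nM. Neither of these differs from compound 1 in one place only, so no single structural change can be read from the series yet.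

Compound 4 (`COc1nc(NC(=O)C(=O)c2cn(C(C)C)c3ccccc23)ns1`) is still unmeasured. It keeps the core of compound 1 and changes only the group on the amide-type nitrogen: a group of 7 heavy atoms (3 carbon, 2 nitrogen, 1 oxygen, 1 sulfur; one five-membered aromatic ring with 3 hetero atoms) in place of a group of 8 heavy atoms (5 carbon, 2 nitrogen, 1 oxygen; one six-membered aromatic ring with 2 hetero atoms), on an amide-type nitrogen. Going by the values given here, no measured pair covers this replacement, so the expectation is a loose one. Among the compounds with values here, compound 1 at 171 nM is the lowest number so far, and both other compounds lie higher, which favours an upward move. The expected move in this assay is a 3.5-fold higher number from compound 1 to compound 4 (0.55 log units; beyond the scatter), a moderate step beyond the scatter. For compound 4 the estimate is 600 nM, with an expected range of 100 nM to 4000 nM.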

Compound 4, concentration lethal to 50% of the cells: > 10000 nM
Compound 4 was reported as a limit (the forecaster's own chance of this, stated with the estimate: 10%); at least 16-fold (1.22 log units) between middle value and limit.
By their numbers in this assay, from the lowest: compound 1; then compound 3; then compound 2.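

In this assay, the ring on the amide-type nitrogen proves decisive with the core of compound 1 held fixed: putting the five-membered aromatic ring with 3 hetero atoms in place of 2-methoxypyrimidin-5-yl gives an at least 58-fold higher number from compound 1 to compound 4 (1.76 log units; beyond the scatter). Compound 4 stands only as a limit, not as a number: the limit of > 10000 nM in this assay, at which 1 of the 4 values shown sits.

Going by these compounds alone, this is the first one-place step, which the earlier compounds could not supply, and it shows that the low number of compound 1 does not survive this replacement.

A single step cannot separate ring size, the sulfur atom and the methoxy group's setting on the new ring as contributors to the change. From the compounds shown here alone, whether a plain phenyl ring, or a pyrimidine ring carrying an amine instead of methoxy, would hold the number of compound 1 remains open.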